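Lengthening the Carbamate Chain on a Selenocyanate Series

The compounds below may be only part of what the source reports. "The series", "measured", "known", "first", "only" and "open" are said of these compounds alone.

The study concerns a small set of aryl selenocyanates and their diselenide. Compound 1 `C=CCOC(=O)Nc1ccc([Se]C#N)cc1` carries an allyl carbamate; in a functional assay on CCRF-CEM cells (Homo sapiens) for cytotoxicity, read by MTT assay, with a stated time of 72 h (on this read-out higher numbers stand for weaker inhibition of growth and lower numbers for stronger inhibition of growth), compound 1 gives 38100 nM, the highest of the two numbers recorded. Its nearest neighbour is compound 2 `C=CCOC(=O)Nc1ccc([Se][Se]c2ccc(NC(=O)OCC=C)cc2)cc1`, the diselenide built from two units of the same carbamate, which in this assay gives 8700 nM; the gap between the two values lies beyond the usual scatter, so compound 2 shows the stronger inhibition of growth of the pair.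

Compound 3 `CCCCCCOC(=O)Nc1ccc([Se]C#N)cc1` has not yet been measured. Relative to compound 1 it differs as follows: pentyl in place of vinyl on a saturated chain carbon bound to an oxygen next to a carbonyl group. The measured pair says nothing about this kind of change, so the expectation rests on compound 1 alone. The expected step, a 1.5-fold lower number from compound 1 to compound 3 (0.18 log units; within the scatter), is small, perhaps toward a lower number but not clearly beyond the scatter. Compound 3 is therefore estimated to give 25000 nM in this assay, within a range from 8000 nM to 70000 nM.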

Compound 3, concentration for total growth inhibition: 46200 nM
Beside the measured number, compound 3's estimate is 1.8-fold (0.27 log units) below it; the range from low to high includes it.
By their numbers in this assay, from the lowest: compound 2; then compounds 1 and 3 (each within the scatter of the next).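

Exchanging the allyl chain of the carbamate for hexyl, which is pentyl in place of vinyl on a saturated chain carbon bound to an oxygen next to a carbonyl group, gives a 1.2-fold higher number from compound 1 to compound 3 (0.08 log units; within the scatter) in this assay. The earlier pair spoke only to the selenocyanate and the diselenide, whereas this step shows that, for these two chains, the read-out does not separate the selenocyanates, with or without the double bond of the allyl group. No supporting measurement bears on why the two chains read alike.

The compounds shown leave open whether a diselenide carrying the hexyl carbamate would stand with compound 2 or with the selenocyanates. They also leave open whether a longer chain, or a chain ending in an amine or a carboxylic acid, would produce a step beyond the scatter at this position.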